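This account rests on a few compounds, and the source may have more. Where it says the series, first, only, none or still open, it means among the compounds named here.

Of the compounds shown here, two sharing one core have been measured in a functional assay on KM12 cells (Homo sapiens) for antiproliferative activity, read by sulforhodamine B assay, with a stated time of 48 h; on this read-out higher numbers stand for weaker inhibition and lower numbers for stronger inhibition. Compound 1 `C/C=C(\C)C(=O)O[C@H]1C=CC(=O)O[C@H]1CCC(=O)[C@H](C)O` gives 18000 nM, and compound 2 `C/C=C(\C)C(=O)O[C@H]1C=CC(=O)O[C@H]1COC(=O)[C@H](C)O` gives 11000 nM, which places compound 2 within the scatter of compound 1. Compound 3 `C/C=C(\C)C(=O)O[C@H]1C=CC(=O)O[C@H]1CNC(=O)[C@H](C)O` keeps the same core and differs from compound 2 in one place: ((1-hydroxyethyl)carbonyl)amino in place of ((1-hydroxyethyl)carbonyl)oxy on a saturated chain carbon bound to a saturated ring carbon, with ((1-hydroxyethyl)carbonyl)amino in place of ((1-hydroxyethyl)carbonyl)oxy on a saturated chain carbon bound to a saturated ring carbon. Going by the values given here, the only measured step at this place, the exchange of ((1-hydroxyethyl)carbonyl)methyl for ((1-hydroxyethyl)carbonyl)oxy, is a 1.6-fold lower number from compound 1 to compound 2 (0.21 log units; within the scatter). With that step inside the scatter, no step beyond the scatter is expected in this assay, and no direction can be expected with confidence. The expected change is a 1.3-fold higher number from compound 2 to compound 3 (0.10 log units; within the scatter). The estimate for compound 3 is 14000 nM, with an expected range from 6000 nM to 33000 nM.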

Compound 3, half-maximal inhibitory concentration: 25000 nM
Beside the measured number, compound 3's estimate is 1.8-fold (0.25 log units) below it; the measured number falls inside the stated range.
By their numbers in this assay, from the lowest: compounds 2, 1 and 3 (each within the scatter of the next, the first and the last beyond it).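

In this assay, going by these compounds alone, ((1-hydroxyethyl)carbonyl)amino in place of ((1-hydroxyethyl)carbonyl)oxy on a saturated chain carbon bound to a saturated ring carbon gives a 2.3-fold higher number from compound 2 to compound 3 (0.36 log units; beyond the scatter) and is the first step at this place to go beyond the scatter, though only modestly. The exchange of ((1-hydroxyethyl)carbonyl)methyl for ((1-hydroxyethyl)carbonyl)amino gives a 1.4-fold higher number from compound 1 to compound 3 (0.14 log units; within the scatter) and so does not separate these two forms. No measurement offered here accounts for the gap between the oxy and amino forms.

On these data alone, it remains open whether a free amine, a carboxylic acid or a longer chain in place of the 1-hydroxyethyl part would move the number further in either direction. Also open, as far as these compounds go, is whether the hydroxy of the 1-hydroxyethyl part, which all three compounds carry, contributes anything.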